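The source may hold more compounds than are shown below. What is called first, only, known or untested is meant among the compounds shown, and "the series" means these compounds.

Measured compounds:
- compound 1 `CC(/C=N/Nc1ccc([N+](=O)[O-])cc1)=N\NC(=O)c1ccc([N+](=O)[O-])cc1`: 980 nM
- compound 2 `CC(/C=N/Nc1ccc([N+](=O)[O-])cc1)=N\NC(=O)c1ccccc1C`: 6000 nM
- compound 3 `CC(/C=N/Nc1ccc([N+](=O)[O-])cc1)=N\NC(=O)c1ccccc1Oc1ccccc1`: > 12000 nM

In a functional assay on cells (Splenocyte, Mus musculus, strain BALB/c) for inhibition, read by scintillation counting and thymidine incorporation, with a stated time of 72 h (a lower number here means a stronger inhibitor, a higher number a weaker inhibitor), compound 1 gives 980 nM. Compound 2 stands at the highest of the two numbers given, 6000 nM, with compound 1 as its nearest neighbour. For compound 3 the value is a limit only, (the limit of > 12000 nM in this assay, at which 1 of the 3 values shown sits), and not a measured number.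

The unmeasured compound 4 `CC(/C=N/Nc1ccc([N+](=O)[O-])cc1)=N\NC(=O)c1ccc(N)cc1` differs from compound 2 at the carbonyl carbon: 4-aminophenyl in place of 2-methylphenyl on a carbonyl carbon. The step that bears on this change is a 6.1-fold higher number from compound 1 to compound 2 (0.79 log units; beyond the scatter), a modest rise when the 4-nitrophenyl gave way to 2-methylphenyl; the further step an at least 2.0-fold higher number from compound 2 to compound 3 (0.30 log units; that floor lies within the scatter) runs in the same direction but only to a limit. Returning to a 4-substituted phenyl, now 4-aminophenyl, is therefore expected to lower the number again in this assay, by roughly a 2.7-fold lower number from compound 2 to compound 4 (0.44 log units; beyond the scatter), landing compound 4 between the values of compound 1 and compound 2. The estimate for compound 4 in this assay is 2200 nM, within 600 nM to 8000 nM.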

Compound 4, half-maximal inhibitory concentration: > 12000 nM
Compound 4 was reported as a limit; the forecaster's own chance of this, stated with the estimate: 8%; middle value at least 5.4-fold (0.73 log units) from the limit.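

In this assay compound 4 gives > 12000 nM, a limit and not a number, so a 4-substituted phenyl on the carbonyl carbon is not enough to restore the value of compound 1: the limit of > 12000 nM in this assay, at which 2 of the 4 values shown sit.

The sharpest reading is the exchange on the aromatic carbon with the rest of the molecule unchanged, an at least 12-fold higher number from compound 1 to compound 4 (1.08 log units; beyond the scatter), which shows that the identity of the group on this phenyl ring matters, not just its place. Against the 2-methylphenyl the change reads as an at least 2.0-fold higher number from compound 2 to compound 4 (0.30 log units; that floor lies within the scatter), and this floor does not separate compound 4 from compound 2.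

On these data alone, how far compound 3 and compound 4 lie beyond the limit remains unknown. As far as these compounds go, it also remains open whether a 4-nitrile, 4-trifluoromethyl or 4-carboxylic acid on the phenyl ring would keep the value of compound 1.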